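Swapping a Dichlorophenyl for a Methoxyphenyl on the Carbonyl

The source may report more compounds than this note shows. Statements on the series, on what has been measured and on what is new or still open speak of the compounds shown alone.

In a functional assay on IGROV-1 cells (Homo sapiens) for cytotoxicity, read by sulforhodamine B assay, with a stated time of 48 h, tested at 0.1 uM (on this read-out lower numbers stand for a stronger effect and higher numbers for a weaker effect at the one concentration tested), compound 1 `COc1ccc(-c2cc(/C=C/C(=O)c3ccc(N)cc3)[nH]n2)cc1` gives 91%. Compound 2 `COc1cc(-c2cc(/C=C/C(=O)c3ccc(Cl)c(Cl)c3)[nH]n2)cc(OC)c1OC` gives 98% in this assay; these two numbers lie within the usual scatter of each other, so neither stands apart, and both point to only a weak effect at the concentration tested. Compound 3 `COc1ccc(C(=O)/C=C/c2cc(-c3cc(OC)c(OC)c(OC)c3)n[nH]2)cc1` has not been measured yet. It differs from compound 2 in one place: 4-methoxyphenyl in place of 3,4-dichlorophenyl on a carbonyl carbon. Going by the values given here, no measured pair shows what this exchange does, so only a small step, a number 5 percentage points lower from compound 2 to compound 3 (within the scatter), is expected, none beyond the scatter. Compound 3 is therefore expected to give about 93% in this assay, most likely between 80% and 102%.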

Compound 3, a percentage reported as activity, at one concentration (the size of the read-out at that concentration, not a potency): 102%
Compound 3: middle estimate off by 9 percentage points, on the low side; the measured number falls inside the stated range.
By their numbers in this assay, from the lowest: compounds 1, 2 and 3 (each within the scatter of the next, the first and the last beyond it).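

In this assay, going by these compounds alone, 4-methoxyphenyl in place of 3,4-dichlorophenyl on a carbonyl carbon gives a number 4 percentage points higher from compound 2 to compound 3 (within the scatter) and so provides the first direct reading of this exchange. At this one concentration, the two rings cannot be told apart at this position, and both compounds show only a weak effect. Nothing available explains this result. Still open, going by these compounds, is whether a carboxylic acid or a longer chain in place of the ring on the carbonyl carbon would give a stronger effect.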